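From phenyl to 2,4-dichlorophenyl on a shared core

The compounds below may be only part of what the source reports. "The series", "measured", "known", "first", "only" and "open" are said of these compounds alone.

Compound 1 `O=C(Cc1csc2nc(-c3ccc(Br)cc3)cn12)N/N=C/c1ccccc1`: 20900 nM
Compound 2 `O=C(Cc1csc2nc(-c3ccc(Br)cc3)cn12)N/N=C/c1ccccc1O`: 2570 nM

In a functional assay on M14 cells (Homo sapiens) for inhibition, read by sulforhodamine B assay, with a stated time of 48 h (a higher number here means a weaker inhibitor of growth, a lower number a stronger inhibitor of growth), compound 1 stands at the higher of the two measured numbers, 20900 nM. Compound 3 `O=C(Cc1csc2nc(-c3ccc(Br)cc3)cn12)N/N=C/c1ccc(Cl)cc1Cl` has not been measured, and it differs from compound 1 by one change: 2,4-dichlorophenyl in place of phenyl on a carbon with a double bond to nitrogen. Among the measured compounds shown here, only one measured step bears on this phenyl, namely an 8.1-fold lower number from compound 1 to compound 2 (0.91 log units; beyond the scatter), which lies beyond the scatter. That step brings in hydroxy rather than chlorine, so it is only a loose guide. A smaller step towards a lower number is expected, a 2.8-fold lower number from compound 1 to compound 3 (0.45 log units; beyond the scatter). Compound 3 is estimated at 7500 nM, with an expected range from 2500 nM to 22000 nM.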

Compound 3, concentration for 50% growth inhibition: 33100 nM
Beside the measured number, compound 3's estimate is 4.4-fold (0.64 log units) below it; measured number outside the range, above it.
By their numbers in this assay, from the lowest: compound 2; then compounds 1 and 3 (each within the scatter of the next).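

In this assay the change to 2,4-dichlorophenyl on a carbon with a double bond to nitrogen gives a 1.6-fold higher number from compound 1 to compound 3 (0.20 log units; within the scatter) and so shows no effect on the number beyond the scatter. The same place read from the other side gives a 13-fold higher number from compound 2 to compound 3 (1.11 log units; beyond the scatter) and so shows that substitution on this phenyl does not by itself bring the lower number seen with the 2-hydroxyphenyl group. No evidence at hand gives a reason for this difference. Still open, on these data alone, is whether a methoxy group or an amine on this phenyl would match hydroxy. A single chlorine also remains to be compared with the two.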